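The source may hold more compounds than are shown below. What is called first, only, known or untested is meant among the compounds shown, and "the series" means these compounds.

Measured compounds:
- compound 1, `COc1ccc(C2=NN(C(=O)C3COc4ccccc4O3)C(c3cccc(F)c3)C2)cc1`: 6720 nM
- compound 2, `COc1ccc(C2=NN(C(=O)c3ccc4c(c3)OCCO4)C(c3ccccc3F)C2)cc1`: 3470 nM

In a functional assay on WM 266-4 cells (Homo sapiens) for inhibition, read by MTT assay, with a stated time of 24 h (on this read-out lower numbers stand for stronger inhibition of growth and higher numbers for weaker inhibition of growth), compound 1 gives 6720 nM, and in this assay compound 2 gives 3470 nM. Compound 2 thus stands at the lower of the two numbers, but the gap to compound 1 lies within the usual scatter of this assay, so the two values cannot be told apart with confidence. Compound 1 and compound 2 differ in more than one place, so their pair shows nothing about the fluorophenyl group on its own.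

Compound 3, `COc1ccc(C2=NN(C(=O)c3ccc4c(c3)OCCO4)C(c3cccc(F)c3)C2)cc1`, has not yet been measured in this assay. It arises from compound 2 by a single rearrangement: 3-fluorophenyl in place of 2-fluorophenyl on a saturated ring carbon. Among the measured compounds shown here, no step between measured compounds describes this change, so the expectation rests on the values of compound 1 and compound 2 alone, and both sit close together. Compound 3 is expected to land near compound 2, with a step of a 1.3-fold higher number from compound 2 to compound 3 (0.11 log units; within the scatter) that does not go beyond the scatter in either direction. For compound 3 in this assay, the estimated value is 4500 nM, with a range from 1800 nM to 11000 nM.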

Compound 3, concentration for 50% growth inhibition: 930 nM
Compound 3: the middle estimate sits 4.8-fold (0.68 log units) above what was measured, outside the stated range (below it).
By their numbers in this assay, from the lowest: compound 3; then compounds 2 and 1 (each within the scatter of the next).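

In this assay, moving the single fluorine on the phenyl group at the saturated ring carbon, with 3-fluorophenyl in place of 2-fluorophenyl, gives a 3.7-fold lower number from compound 2 to compound 3 (0.57 log units; beyond the scatter) and so shows that the position of the fluorine on this group matters, even though the atoms and the counts of the two groups are identical. The carbonyl carbon also proves sensitive: with 3-fluorophenyl held fixed, 2,3-dihydro-1,4-benzodioxin-6-yl in place of 2,3-dihydro-1,4-benzodioxin-2-yl gives a 7.2-fold lower number from compound 1 to compound 3 (0.86 log units; beyond the scatter), a change that the earlier pair of compounds, differing in more than one place, could not isolate. Nothing measured here offers an explanation for either step.

On these data alone, it remains open how plain phenyl, a chlorophenyl group or a pyridyl group would compare with 3-fluorophenyl on the saturated ring carbon, and whether fluorine is needed there at all. It is also unknown whether the effect of moving the fluorine carries over to a compound with 2,3-dihydro-1,4-benzodioxin-2-yl on the carbonyl carbon, or to one with a hydroxyl group in place of the methoxy group.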